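A few compounds are considered here, and "the series" means these few. Any claim that something is new, unique, unknown or untested is made for them only; others in the source may bear on it.

Compound 1 `Cc1cc(=O)n(-c2ccccc2)nc1C(=O)Nc1ccc(Oc2ccnc3cc(OCCCN4CCC(C)CC4)ccc23)c(F)c1` gives 270 nM in a functional assay on NCI-H460 cells (Homo sapiens) for inhibition, read by MTT assay, with a stated time of 72 h; a lower number here means a stronger inhibitor, a higher number a weaker inhibitor.
Compound 2 `COc1cc2c(Oc3ccc(NC(=O)c4nn(-c5ccccc5)c(=O)cc4C)cc3F)ccnc2cc1OCCCN1CCN(C)CC1` gives 360 nM in this assay.

Compound 2 has the higher of the two numbers, but its gap to compound 1 lies within the scatter, so the two read as alike. Compound 3 `COc1cc2c(Oc3ccc(NC(=O)c4nn(-c5ccccc5C)c(=O)cc4C)cc3F)ccnc2cc1OCCCN1CCN(C)CC1` differs from compound 2 by one change: methyl in place of hydrogen on an aromatic carbon. Within the data shown here, no measured pair shows this change, so there is no step to lean on. The expected step of a 1.1-fold higher number from compound 2 to compound 3 (0.05 log units; within the scatter) is small, in no settled direction, and not beyond the scatter. Compound 3 is therefore estimated at 400 nM, within a range from 150 nM to 1100 nM.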

Compound 3, half-maximal inhibitory concentration: 3420 nM
For compound 3 the middle estimate is 8.6-fold (0.93 log units) below the measured one; the whole stated range lies below it.
By their numbers in this assay, from the lowest: compounds 1 and 2 (each within the scatter of the next); then compound 3.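

In this assay the change from phenyl to 2-methylphenyl gives a 9.5-fold higher number from compound 2 to compound 3 (0.98 log units; beyond the scatter) and so weakens inhibition well past the usual scatter. Compounds 1 and 2 both carry the plain phenyl, so only now does this aromatic carbon, ortho to a large group, prove sensitive to a single added methyl. No measurement here accounts for the loss.
Going by these compounds, it remains open whether a fluorine or a methoxy group at this carbon would weaken inhibition as much. On these data alone, it is also open whether methyl on another carbon of this ring would do so.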